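The source may hold more compounds than are shown below. What is called first, only, known or untested is meant among the compounds shown, and "the series" means these compounds.

Measured so far in an assay on CHO cells for displacement of a labelled ligand from prostacyclin receptor (Homo sapiens), read by scintillation counting, with a stated time of 30 min; a higher number here means a weaker inhibitor, a lower number a stronger inhibitor:
compound 2, `Cc1cc(OC[C@@H]2COc3ccccc3O2)ccc1C(=O)n1c(C)c(CC(=O)O)c2ccccc21`: 570 nM
compound 1, `Cc1c(CC(=O)O)c2cc(F)ccc2n1C(=O)c1ccc(OC[C@@H]2CN(C)c3ccccc3O2)cc1Cl`: 200 nM

Compound 2 stands at the higher of the two numbers; compound 1 sits beyond the scatter below it. Going by the values given here, compound 1 differs from compound 2 in several places at once, so the pair does not isolate any one change and no step is drawn from it.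

Compound 3, `Cc1cc(OCC2Cc3ccccc3N2C)ccc1C(=O)n1c(C)c(CC(=O)O)c2ccccc21`, is not yet measured. Against compound 2 the change is 1-methyl-2,3-dihydro-1H-indol-2-yl in place of 2,3-dihydro-1,4-benzodioxin-2-yl on a saturated chain carbon bound to an oxygen on an aromatic ring. Among the compounds with values here, no measured pair carries this change alone. The bicycle of compound 1 also holds a methyl on nitrogen and compound 1 gives 200 nM, but its other differences leave that as a loose hint only. The step is expected to be small, within or only just beyond the scatter, with a slight lean toward a lower number: a 1.4-fold lower number from compound 2 to compound 3 (0.15 log units; within the scatter). Compound 3 is therefore estimated at 400 nM, with a range of 120 nM to 1300 nM.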

Compound 3, inhibition constant: > 10000 nM
Compound 3 gave a limit, no number; the forecaster's own chance of this, stated with the estimate: 5%; middle value at least 25-fold (1.39 log units) away from the limit.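

In this assay compound 3 gives > 10000 nM, which is a limit of the assay and not a number. On a saturated chain carbon bound to an oxygen on an aromatic ring, 1-methyl-2,3-dihydro-1H-indol-2-yl in place of 2,3-dihydro-1,4-benzodioxin-2-yl gives an at least 17-fold higher number from compound 2 to compound 3 (1.24 log units; beyond the scatter). This place therefore discriminates sharply between these two bicyclic groups, even though each has the same count of heavy atoms.

Going by these compounds alone, the single step changes ring size, the hetero atoms, the methyl on nitrogen and the defined stereocentre together, which leaves open which of these carries the loss. At the same place, 2,3-dihydro-1-benzofuran-2-yl, with a five-membered ring holding oxygen, or 2,3-dihydro-1H-indol-2-yl, with hydrogen on the ring nitrogen, would help to separate them.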